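The source may hold more compounds than are shown below. What is called first, only, known or untested is meant among the compounds shown, and "the series" means these compounds.

Measured so far:
- compound 1 `O=C1NC(=O)/C(=C\c2ccc(OCC(=O)N3N=C(c4ccc(F)cc4)CC3c3ccc(C(F)(F)F)cc3)cc2)S1`, which gives 1300 nM
- compound 2 `Cc1ccc(C2CC(c3ccc(F)cc3)=NN2C(=O)COc2ccc(/C=C3/SC(=O)NC3=O)cc2)cc1`, which gives 1800 nM
- compound 3 `O=C1NC(=O)/C(=C\c2ccc(OCC(=O)N3N=C(c4ccc(F)cc4)CC3c3ccc(Cl)c(Cl)c3)cc2)S1`, which gives 800 nM

All three share one core and differ only in the aryl group on a saturated ring carbon. In an assay on cells for inhibition of histone deacetylase 4 (Homo sapiens), read by fluorescence, with a stated time of 30 min (a lower number here means a stronger inhibitor, a higher number a weaker inhibitor), compound 2 holds the highest number of the three: the gap on one side a 1.4-fold higher number from compound 1 to compound 2 (0.14 log units; within the scatter) stays within the scatter, while the gap to compound 3 a 2.3-fold lower number from compound 2 to compound 3 (0.35 log units; beyond the scatter) is modest but beyond it. The step from compound 1 to compound 3 a 1.6-fold lower number from compound 1 to compound 3 (0.21 log units; within the scatter) is within the scatter.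

Compound 4 `Cc1ccc(C2CC(c3ccc(F)cc3F)=NN2C(=O)COc2ccc(/C=C3/SC(=O)NC3=O)cc2)cc1` has not been measured. It differs from compound 2 in one place: fluoro in place of hydrogen on an aromatic carbon. This change sits on the 4-fluorophenyl ring, which is the same in compound 1, compound 2 and compound 3. Among the compounds with values here, none of the measured steps alters that ring; each of them swaps the aryl group on the saturated ring carbon. So no measured step bears directly on this change, and a single added fluoro is a small alteration. The expectation is therefore a step of a 1.1-fold lower number from compound 2 to compound 4 (0.05 log units; within the scatter) of no size beyond the scatter. On that basis compound 4 is estimated at 1600 nM, within a range from 700 nM to 3600 nM.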

Compound 4, half-maximal inhibitory concentration: 1500 nM
Estimate against measurement, compound 4: 1.1-fold (0.03 log units) above; low and high end bracket the measured number.
By their numbers in this assay, from the lowest: compounds 3, 1, 4 and 2 (each within the scatter of the next, the first and the last beyond it).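

In this assay, the change from 4-fluorophenyl to 2,4-difluorophenyl gives a 1.2-fold lower number from compound 2 to compound 4 (0.08 log units; within the scatter), so compound 2 and compound 4 cannot be told apart by this measurement. The earlier compounds shown here differed only in the aryl group on the saturated ring carbon and said nothing about the 4-fluorophenyl ring, whereas this pair shows that a fluoro can stand on this aromatic carbon, ortho to a large group and meta to a fluoro group, with no change beyond the usual scatter. No measurement at hand explains why this added fluoro leaves the number within the scatter.

The compounds shown leave open whether a larger group at this same place, such as a methoxy group, an amine or a carboxylic acid, would also leave the number within the scatter. They also leave open whether the added fluoro would behave the same way alongside the 4-(trifluoromethyl)phenyl of compound 1 or the 3,4-dichlorophenyl of compound 3, as the one pair shown carries 4-methylphenyl.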